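Trading the dichlorophenyl for a fluorophenyl on the diamide

The source may report more compounds than this note shows. Statements on the series, on what has been measured and on what is new or still open speak of the compounds shown alone.

Of the compounds shown here, three on a shared core have been measured in an in vitro functional assay on HEK293-A cells for antagonist activity at metabotropic glutamate receptor 5 (Rattus norvegicus), read by calcium flux; a higher number here means a weaker inhibitor, a lower number a stronger inhibitor. Compound 1 `COc1ccccc1C(=O)Nc1cccc(NC(=O)c2cccc(F)c2)c1` gives 6480 nM and compound 2 `O=C(Nc1cccc(NC(=O)c2ccccc2Cl)c1)c1cccc(Cl)c1` gives 2620 nM. Compound 3 `O=C(Nc1cccc(NC(=O)c2ccc(Cl)c(Cl)c2)c1)c1cccc(Cl)c1` reaches only the limit of this assay, > 30000 nM, so no number stands for it; it is the single one of the three at the limit of > 30000 nM in this assay, at which 1 of the 3 values shown sits. Within the data shown here, the one measured step that touches it, an at least 11-fold higher number from compound 2 to compound 3 (1.05 log units; beyond the scatter), carried it from a number to that limit.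

Compound 4 `O=C(Nc1cccc(NC(=O)c2cccc(Cl)c2)c1)c1cccc(F)c1` is compound 3 with 3-fluorophenyl in place of 3,4-dichlorophenyl on a carbonyl carbon. The step from compound 2 to compound 3 shows that the 3,4-dichlorophenyl on this carbonyl carbon went with a loss beyond the scatter, and compound 1, which carries a 3-fluorophenyl on a carbonyl carbon, gives a number within this assay. The chemist therefore expects compound 4 to return to a measurable number, the step being estimated at an at least 6.0-fold lower number from compound 3 to compound 4 (0.77 log units; beyond the scatter). His estimate for compound 4 is 5000 nM, between 1500 nM and 20000 nM.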

Compound 4, half-maximal inhibitory concentration: > 30000 nM
Compound 4: only a limit was reported; the forecaster's own chance of this, stated with the estimate: 20%; at least 6.0-fold (0.77 log units) between middle value and limit.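

In this assay compound 4 gives > 30000 nM as a limit and not a number, so 3-fluorophenyl in place of 3,4-dichlorophenyl on this carbonyl carbon brings no number back. The step between these two compounds cannot be read because both stand at the same limit: the limit of > 30000 nM in this assay, at which 2 of the 4 values shown sit. The other two steps are an at least 11-fold higher number from compound 2 to compound 4 (1.05 log units; beyond the scatter) and an at least 4.6-fold higher number from compound 1 to compound 4 (0.66 log units; beyond the scatter), so 3-fluorophenyl did not keep a number once 3-chlorophenyl replaced the 2-methoxyphenyl of compound 1, and among the three compounds carrying 3-chlorophenyl only compound 2, with its 2-chlorophenyl, has a number.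

From the compounds shown here alone, how far compound 3 and compound 4 lie past the limit stays open. So does whether a 2-fluorophenyl, or a phenyl bearing an amine, would give a number at this carbonyl carbon.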